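This account rests on a few compounds, and the source may have more. Where it says the series, first, only, none or still open, it means among the compounds named here.

Measured in a physicochemical assay for acid dissociation:

- compound 1 `Cc1nc2c(CCc3ccccc3)cccn2c1N`: 7.3
- compound 2 `Cc1nc2c(/C=C/Cc3ccccc3)cccn2c1N`: 6.75
- compound 3 `Cc1nc2c(OCc3ccccc3)cccn2c1C`: 7

At 7, compound 3 stands within the usual scatter of both other compounds, so this assay does not separate it from either of them. The next step leads to compound 4 `Cc1nc2c(OCc3ccccc3)cccn2c1N`, with a single structural change: amino in place of methyl on an aromatic carbon. This places amino in place of methyl on an aromatic carbon.

Going by the values given here, no measured pair isolates this exchange, and its effect can only be judged indirectly. Compound 1 at 7.3 and compound 2 at 6.75 already carry the amino group, but each also differs from compound 4 elsewhere on the shared core. Neither value falls outside the scatter of compound 3, so the exchange is not expected to produce a clear shift in either direction. The estimated change, no change at the digits printed from compound 3 to compound 4 (within the scatter), is expected to stay within the scatter. For compound 4 the estimated value is 7, with an expected range of 6.6 to 7.4.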

Compound 4, acid dissociation constant: 6.81
For compound 4 the middle estimate is 0.19 log units above the measured one, within the range that was stated.
By their numbers in this assay, from the lowest: compounds 2, 4, 3 and 1 (each within the scatter of the next, the first and the last beyond it).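

In this assay, the exchange of methyl for amino on an aromatic carbon of the five-membered aromatic ring can now be read directly, with the rest of the structure unchanged: a number 0.19 log units lower from compound 3 to compound 4 (within the scatter). Going by these compounds alone, this assay therefore does not separate amino from methyl at this position, a point that the earlier compounds could only suggest indirectly as they differed from compound 4 elsewhere on the shared core. Nothing available bears on the reason for this result.

The compounds shown leave open whether a different group here, such as a hydroxyl or a dimethylamino group, would stand apart from methyl and amino in this assay. Also open, from the compounds shown here alone, is whether the exchange would read the same with the side chain of compound 1 or compound 2 on the shared core.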